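Substitution at the ring amine nitrogen of compound 1

The source may report more compounds than this note shows. Statements on the series, on what has been measured and on what is new or still open speak of the compounds shown alone.

Among the compounds with values here, compound 1 `NC(=O)c1c(NC(=O)c2ccccc2Cl)sc2c1CCNC2` gives the highest of the three numbers measured so far in a functional assay on MKN-74 cells (Homo sapiens) for antiproliferative activity, with a stated time of 24 h (on this read-out lower numbers stand for stronger inhibition and higher numbers for weaker inhibition), at 28700 nM. Its nearest neighbour is compound 3 `NC(=O)c1c(NC(=O)c2ccccc2Cl)sc2c1CCN(C(=S)Nc1cccc3ccccc13)C2`, which in this assay gives 20700 nM; the furthest is compound 2 `NC(=O)c1c(NC(=O)c2ccccc2Cl)sc2c1CCN(C(=S)Nc1ccccc1)C2`, which gives 15600 nM. Both gaps from compound 1 lie within the scatter. Compound 4 `NC(=O)c1c(NC(=O)c2ccccc2Cl)sc2c1CCN(C(=S)Nc1ccccc1Br)C2` differs from compound 1 by a group of 10 heavy atoms (7 carbon, 1 nitrogen, 1 sulfur, 1 bromine; one six-membered aromatic ring of carbon only) in place of a hydrogen atom, on an amine nitrogen in a ring. Within the data shown here, two measured steps bear on this change. The step of a 1.8-fold lower number from compound 1 to compound 2 (0.26 log units; within the scatter) places a group of 9 heavy atoms on the same amine nitrogen in a ring and stays within the scatter; the step of a 1.3-fold higher number from compound 2 to compound 3 (0.12 log units; within the scatter) exchanges phenyl for naphthalen-1-yl on the amide-type nitrogen of that group and also stays within the scatter. Neither variation at this nitrogen has moved this assay beyond its noise, so the group entering in compound 4 is expected to behave alike, with a step of a 1.6-fold lower number from compound 1 to compound 4 (0.20 log units; within the scatter) that is expected to remain within the scatter. Compound 4 is therefore estimated at 18000 nM, with an expected range of 9000 nM to 36000 nM.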

Compound 4, half-maximal inhibitory concentration: 10800 nM
For compound 4 the middle estimate is 1.7-fold (0.22 log units) above the measured one; low and high end bracket the measured number.
By their numbers in this assay, from the lowest: compounds 4, 2, 3 and 1 (each within the scatter of the next, the first and the last beyond it).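

In this assay, within the data shown here, a group on the amine nitrogen in a ring gives a step beyond the scatter for the first time, though only a modest one: a 2.7-fold lower number from compound 1 to compound 4 (0.42 log units; beyond the scatter). The bromo group cannot be separated from the rest of that group, since a 1.4-fold lower number from compound 2 to compound 4 (0.16 log units; within the scatter) and a 1.9-fold lower number from compound 3 to compound 4 (0.28 log units; within the scatter) both stay within the scatter, so only the comparison with the unsubstituted compound 1 clears the noise. No measurement available here accounts for this step.

From the compounds shown here alone, it remains open whether chloro, fluoro or methoxy in place of the bromo group would give a number distinct from that of compound 2. Also unresolved is whether an alkyl chain in place of the aromatic ring would keep the step from compound 1.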